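Dimethoxyphenyl in place of methoxyphenyl: expected growth inhibition

The source may hold more compounds than are shown below. What is called first, only, known or untested is meant among the compounds shown, and "the series" means these compounds.

Measured so far in a functional assay on THP-1 cells (Homo sapiens) for inhibition, read by sulforhodamine B assay, with a stated time of 48 h, tested at 50 uM; on this read-out lower numbers stand for less inhibition of growth and higher numbers for more inhibition of growth at the one concentration tested:

Compound 1 `COc1ccccc1/C=C/C(=O)/C=C/c1ccc(OCc2cn(CCCOc3cc(=O)oc4ccccc34)nn2)c(OC)c1`: 50%
Compound 2 `COc1ccccc1/C=C/C(=O)/C=C/c1ccc(OCc2cn(CCOc3cc(=O)oc4ccccc34)nn2)c(OC)c1`: 75%
Compound 3 `COc1cc(/C=C/C(=O)/C=C/c2cc(OC)c(OC)c(OC)c2)ccc1OCc1cn(CCOc2cc(=O)oc3ccccc23)nn1`: 99%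

Compound 1 stands lowest of the three numbers; compound 2 lies nearer to it, compound 3 furthest, and both gaps lie beyond the scatter. Among the measured compounds shown here, no step is computed for compound 1 against compound 2; their two values simply show compound 2 the higher.

The unmeasured compound 4 `COc1ccc(/C=C/C(=O)/C=C/c2ccc(OCc3cn(CCCOc4cc(=O)oc5ccccc45)nn3)c(OC)c2)cc1OC` is reached from compound 1 by 3,4-dimethoxyphenyl in place of 2-methoxyphenyl on a double-bonded chain carbon bound to a double-bonded chain carbon.

For the measured compounds named here, one measured step bears on this: a number 24 percentage points higher from compound 2 to compound 3 (beyond the scatter). That exchange also replaces the 2-methoxyphenyl, there by a 3,4,5-trimethoxyphenyl, and carries a rise beyond the scatter. The change to compound 4 adds one methoxy fewer, so a rise of comparable or somewhat smaller size in this assay is expected for compound 4 relative to compound 1, in the upward direction, as a number 20 percentage points higher from compound 1 to compound 4 (beyond the scatter).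

Going by the values given here, compound 4 is therefore estimated at 70%, with a range from 52% to 90%, since only a single analogous step supports the expectation.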

Compound 4, percent growth inhibition at one concentration: 73%
The estimate for compound 4 lay 3 percentage points below the measured number; the measured number falls inside the stated range.
By their numbers in this assay, from the lowest: compound 1; then compounds 4 and 2 (each within the scatter of the next); then compound 3.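

Working notes on the series: in this assay, 3,4-dimethoxyphenyl in place of 2-methoxyphenyl on a double-bonded chain carbon bound to a double-bonded chain carbon gives a number 23 percentage points higher from compound 1 to compound 4 (beyond the scatter) and so shows that this position responds on the chain of compound 1 as well. Until now, the only step at this position was a number 24 percentage points higher from compound 2 to compound 3 (beyond the scatter) on the chain of compound 2, with 3,4,5-trimethoxyphenyl as the entering group, so the rise now holds for two entering groups on two chains, and no listed compound goes against it. Nothing at hand explains this rise.

As far as these compounds go, the pairing of each entering group with the other chain remains open, so the separate contributions of chain and aryl group cannot be read from these compounds, and each reading rests on growth inhibition at a single concentration. Also open, from the compounds shown here alone, is whether the rise needs methoxy groups at all, since a hydroxyphenyl, an aminophenyl or a carboxylic acid on the ring at this position would test that directly.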